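The source may hold more compounds than are shown below. What is called first, only, known or untested is meant among the compounds shown, and "the series" means these compounds.

Three compounds have been measured in an ADME assay on MDCK cells (Canis lupus familiaris) for cytotoxicity, read by MTT assay, with a stated time of 48 h; a higher number here means that more compound is tolerated, a lower number that less compound is tolerated:

Compound 1 `COc1ccc([C@H]2CC(C)(O)[C@@H]3CC[C@@H](C)C[C@H]3O2)c(OC)c1OC` gives > 857000 nM, which is a limit of the assay rather than a number.
Compound 2 `COc1ccc([C@H]2CC(C)(F)[C@@H]3CC[C@@H](C)C[C@H]3O2)c(OC)c1` gives 379000 nM.
Compound 3 `COc1ccc([C@H]2CC(C)(F)[C@@H]3CC[C@@H](C)C[C@H]3O2)cc1OC` gives 20000 nM.

Among the two compounds that gave a number, compound 3 stands lowest; compound 2 lies well above it, beyond the usual scatter. The value of compound 1 is only a limit (the limit of > 857000 nM in this assay, at which 1 of the 3 values shown sits).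

Compound 4 `COc1ccc([C@H]2CC(C)(F)[C@@H]3CC[C@@H](C)C[C@H]3O2)c(OC)c1OC` is compound 3 with methoxy in place of hydrogen on an aromatic carbon. Among the measured compounds shown here, no pair of the measured compounds differs in one place only, so there is no measured step to lean on directly. Compound 1 carries the same three methoxy groups as compound 4 but a hydroxyl where compound 4 has fluorine, and compound 1 reached > 857000 nM, a limit. Compound 3, with two methoxy groups, gave 20000 nM. On this slim basis the step from compound 3 to compound 4 is expected to go upward, a 3.5-fold higher number from compound 3 to compound 4 (0.54 log units; beyond the scatter), probably beyond the scatter but with wide uncertainty. Compound 4 is therefore estimated at 70000 nM, with a range from 12000 nM to 450000 nM.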

Compound 4, half-maximal cytotoxic concentration: 133000 nM
Estimate against measurement, compound 4: 1.9-fold (0.28 log units) below; the range from low to high includes it.
By their numbers in this assay, from the lowest: compound 3; then compound 4; then compound 2. At a limit, above all of these: compound 1.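

In this assay, methoxy in place of hydrogen on an aromatic carbon ortho to a large group and ortho to a methoxy group goes with more compound being tolerated: a 6.7-fold higher number from compound 3 to compound 4 (0.82 log units; beyond the scatter). The same exchange at a different aromatic carbon of the ring goes the other way, a 2.8-fold lower number from compound 2 to compound 4 (0.45 log units; beyond the scatter), so among these compounds the direction of the change depends on where the methoxy group enters. Fluoro in place of hydroxy on a saturated ring carbon gives an at least 6.4-fold lower number from compound 1 to compound 4 (0.80 log units; beyond the scatter), a step that starts from a limit rather than a number: the limit of > 857000 nM in this assay, at which 1 of the 4 values shown sits.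

Going by these compounds, it remains open how an amine or a chlorine atom would behave on the same aromatic carbon. Also open, on these data alone, is what a carboxylic acid would do in place of the fluorine on the saturated ring carbon.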